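Thioamide pair: bromo to trifluoromethyl on two cores

The source may hold more compounds than are shown below. What is called first, only, known or untested is meant among the compounds shown, and "the series" means these compounds.

The measured compounds in a functional assay on HepG2 cells (Homo sapiens) for cytotoxicity, with a stated time of 24 h (a lower number here means a stronger inhibitor, a higher number a weaker inhibitor), are these:

Compound 1 `COc1cc(Cl)ccc1C(=S)Nc1cc(Br)ccc1O` gives 6530 nM.
Compound 2 `COc1cc(Cl)ccc1C(=S)Nc1cc(C(F)(F)F)ccc1O` gives 5740 nM.
Compound 3 `COc1ccc(Cl)cc1C(=S)Nc1cc(Br)ccc1O` gives 8740 nM.

Compound 4 `COc1ccc(Cl)cc1C(=S)Nc1cc(C(F)(F)F)ccc1O` has not been measured yet.

Compounds 1 and 3 are built from the same atoms joined differently; the difference between the two cores is not broken down here. In this assay compound 3 stands highest of the three numbers, but the gaps to compound 1 and to compound 2 are both within the scatter, so no order among them is claimed.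

One structural change appears twice in this set. From compound 1 to compound 2 it is trifluoromethyl in place of bromo on an aromatic carbon, and in this assay it made a 1.1-fold lower number from compound 1 to compound 2 (0.06 log units; within the scatter). From compound 3 to compound 4 the change is trifluoromethyl in place of bromo on an aromatic carbon. Among the compounds with values here, the two place descriptions are identical word for word, so the change from compound 3 to compound 4 is the same kind of change as the one from compound 1 to compound 2, made on the other core.

Because the earlier step of a 1.1-fold lower number from compound 1 to compound 2 (0.06 log units; within the scatter) lay within the scatter, the expectation for compound 4 is a step of about the same size, a 1.1-fold lower number from compound 3 to compound 4 (0.06 log units; within the scatter), resting on that single earlier pair alone. Compound 4 is therefore estimated at 7700 nM in this assay, with a range from 3800 nM to 15500 nM.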

Compound 4, half-maximal inhibitory concentration: 5860 nM
Beside the measured number, compound 4's estimate is 1.3-fold (0.12 log units) above it; low and high end bracket the measured number.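

On the second core, trifluoromethyl in place of bromo gives a 1.5-fold lower number from compound 3 to compound 4 (0.17 log units; within the scatter) in this assay, a step that stays within the usual scatter of the measurement. Set beside the earlier step, the change reads alike on both cores: the same change on two cores in this assay, a 1.1-fold lower number (0.06 log units; within the scatter) from compound 1 to compound 2 and a 1.5-fold lower number (0.17 log units; within the scatter) from compound 3 to compound 4, 1.3-fold (0.12 log units) apart, within the scatter of two such steps. This shows that, in these two pairs, the exchange of bromo for trifluoromethyl carries from one core to the other without a step that can be told apart from the scatter, but it does not show that a real effect of the change is conserved, as neither step stands clear of the scatter and two pairs set no rule for the wider series.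

The compounds shown leave open whether a different group in the same place, such as a nitrile, an amine or a carboxylic acid, would move the number beyond the scatter on either core, and whether any such step would then carry from one core to the other. They also leave open what would happen if the thioamide gave way to a plain amide with a carbonyl, or if the hydroxy group gave way to a methoxy group.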